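The source may report more compounds than this note shows. Statements on the series, on what has been measured and on what is new or still open speak of the compounds shown alone.

Three compounds sharing one core have been followed in an ADME assay on the whole organism (plasma) for pharmacokinetics, with Rhesus monkey (Macaca mulatta) as the target, read by LC-MS, at a dose of 1 mg/kg by the oral route; a lower number here means less compound in the circulation, a higher number more compound in the circulation at the dose given. There, compound 1 (`COc1ccc2nc(COc3ccc(CC4(O)SC(=O)NC4=O)cc3)n(C)c2c1`) gives 7.33 ng.h/mL, compound 2 (`COc1ccc2nc(COc3ccc(CC(SC)C(N)=O)cc3)n(C)c2c1`) gives 16.9 ng.h/mL and compound 3 (`COc1ccc2nc(COc3ccc(CC(SC)C(=O)O)cc3)n(C)c2c1`) gives 76.8 ng.h/mL. Compound 3 therefore holds the highest number of the three, and the measured steps to it are a 4.5-fold higher number from compound 2 to compound 3 (0.66 log units; beyond the scatter) and a 10-fold higher number from compound 1 to compound 3 (1.02 log units; beyond the scatter). The remaining step, a 2.3-fold higher number from compound 1 to compound 2 (0.36 log units; beyond the scatter), is smaller.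

The next compound is compound 4 (`COc1ccc2nc(COc3ccc(CC(C(N)=O)S(C)(=O)=O)cc3)n(C)c2c1`), in which carbamoyl(methylsulfonyl)methyl replaces carboxy(methylsulfanyl)methyl on a saturated chain carbon bound to an aromatic carbon: carbamoyl(methylsulfonyl)methyl in place of carboxy(methylsulfanyl)methyl on a saturated chain carbon bound to an aromatic carbon. One part of this change has a measured counterpart, run in the opposite direction. The step that placed hydroxy in place of amino on a carbonyl carbon was a 4.5-fold higher number from compound 2 to compound 3 (0.66 log units; beyond the scatter), a modest one, so returning to the carbamoyl group is expected to lower the number by a similar amount. The other part, methylsulfanyl to methylsulfonyl, has no measured step among these compounds, which leaves the size uncertain and widens the range. The expected result is a modest to large fall, estimated as a 5.1-fold lower number from compound 3 to compound 4 (0.71 log units; beyond the scatter). Compound 4 is expected to give about 15 ng.h/mL, with an estimated range from 4 ng.h/mL to 55 ng.h/mL.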

Compound 4, area under the concentration-time curve: 27 ng.h/mL
Estimate against measurement, compound 4: 1.8-fold (0.26 log units) below; the measured number falls inside the stated range.
By their numbers in this assay, from the lowest: compound 1; then compounds 2 and 4 (each within the scatter of the next); then compound 3.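

In this assay, among the compounds shown here, the first measured change at the sulfur group, methylsulfonyl in place of methylsulfanyl with the carbamoyl group held, stays within the scatter (a 1.6-fold higher number from compound 2 to compound 4 (0.20 log units; within the scatter)). The full replacement of carboxy(methylsulfanyl)methyl by carbamoyl(methylsulfonyl)methyl on a saturated chain carbon bound to an aromatic carbon does lie beyond the scatter (a 2.8-fold lower number from compound 3 to compound 4 (0.45 log units; beyond the scatter)), so among these compounds the carboxy compound, compound 3, keeps the highest number, and the oxidation level of the sulfur does not by itself produce a step that can be told from repeat scatter. The open-chain carbamoyl compound with methylsulfonyl also stands clear of the hydroxy-dioxo-thiazolidinyl compound (a 3.7-fold higher number from compound 1 to compound 4 (0.57 log units; beyond the scatter)), which extends to a second open-chain amide what compound 2 had shown.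

The data shown offer no measurement that would account for any of these steps. On these data alone, it remains open whether a carboxylic acid carrying methylsulfonyl would hold the number seen for compound 3, and how a methylsulfinyl group or a longer alkylsulfonyl chain would behave at this position.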